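A few compounds are considered here, and "the series" means these few. Any claim that something is new, unique, unknown or untested is made for them only; others in the source may bear on it.

Measured compounds:
- compound 1 `Cc1cc(-c2c(F)cc3c(=O)ccn(C4CC4)c3c2F)cc(C)n1`: 15000 nM
- compound 2 `Cc1cc(-c2c(F)cc3c(=O)c(Cc4c(O)cccc4O)cn(C4CC4)c3c2F)cc(C)n1`: 250 nM

In a functional assay on P388 cells (Mus musculus) for cytotoxicity (a lower number here means a stronger inhibitor, a higher number a weaker inhibitor), compound 1 gives 15000 nM, the highest of the two numbers shown, and compound 2 gives 250 nM. Among the compounds with values here, the single measured step is a 60-fold lower number from compound 1 to compound 2 (1.78 log units; beyond the scatter), a large step beyond the scatter.

Compound 3 `Cc1cc(-c2c(F)cc3c(=O)c(Cc4ccccc4N)cn(C4CC4)c3c2F)cc(C)n1` has not yet been measured. It differs from compound 1 by 2-aminobenzyl in place of hydrogen on an aromatic carbon. Within the data shown here, the only step that bears on this change is the one from compound 1 to compound 2, where a benzyl group bearing two hydroxyls entered at the same aromatic carbon; here a benzyl group bearing one amino group enters instead. Among the measured compounds shown here, on the evidence of that step, a lowering of the number from compound 1 is expected, probably a substantial one, though the single precedent leaves its size uncertain. The expected step is a 21-fold lower number from compound 1 to compound 3 (1.33 log units; beyond the scatter). For compound 3 the estimate in this assay is 700 nM, with a range from 150 nM to 4000 nM.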

Compound 3, half-maximal inhibitory concentration: 2100 nM
The estimate for compound 3 lay 3.0-fold (0.48 log units) below the measured number, and the stated range covers the measured number.
By their numbers in this assay, from the lowest: compound 2; then compound 3; then compound 1.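

In this assay, a second benzyl group at this aromatic carbon also lowers the number: 2-aminobenzyl gives a 7.1-fold lower number from compound 1 to compound 3 (0.85 log units; beyond the scatter), so the gain is not confined to the 2,6-dihydroxybenzyl group of compound 2. The substituents on the benzyl ring still matter, as 2-aminophenyl in place of 2,6-dihydroxyphenyl on the same chain carbon gives an 8.4-fold higher number from compound 2 to compound 3 (0.92 log units; beyond the scatter), leaving compound 2 the lowest of the three. Nothing at hand accounts for this difference between the two benzyl groups.

The compounds shown leave open how much of the gain comes from the benzyl group itself and how much from its substituents, a question that plain benzyl, 2-hydroxybenzyl or 2,6-diaminobenzyl would address. They also leave open whether a longer chain between the core and the ring, or a carboxylic acid in place of the ring, would keep any of the gain.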